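The source may hold more compounds than are shown below. What is called first, only, known or untested is meant among the compounds shown, and "the series" means these compounds.

Of the compounds shown here, three have been tested in a functional assay on A549 cells (Homo sapiens) for cytotoxicity, read by MTT assay, with a stated time of 48 h; a higher number here means a weaker inhibitor, a lower number a stronger inhibitor. Compound 1 (`COC(=O)[C@@H]1CCCN1C(=O)C1=C(C)NC(=S)NC1c1cccc(OCCCCCOc2cccc(C3NC(=S)NC(C)=C3C(=O)N3CCC[C@H]3C(=O)OC)c2)c1`) gives a measured half-maximal inhibitory concentration of 184 ug/mL. Compound 2 (`COC(=O)[C@@H]1CCCN1C(=O)C1=C(C)NC(=S)NC1c1cccc(OC/C=C\COc2cccc(C3NC(=S)NC(C)=C3C(=O)N3CCC[C@H]3C(=O)OC)c2)c1`) gives no number, only a limit of the assay, > 200 ug/mL. Compound 3 (`COC(=O)[C@@H]1CCCN1C(=O)C1=C(C)NC(=S)NC1c1ccc(OC/C=C\COc2ccc(C3NC(=S)NC(C)=C3C(=O)N3CCC[C@H]3C(=O)OC)cc2OC)c(OC)c1`) likewise gives only a limit, > 200 ug/mL. This places compound 3 in a shared position on the scale: the limit of > 200 ug/mL in this assay, at which 2 of the 3 values shown sit.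

Compound 4 (`COC(=O)[C@@H]1CCCN1C(=O)C1=C(C)NC(=S)NC1c1ccc(OC/C=C/COc2ccc(C3NC(=S)NC(C)=C3C(=O)N3CCC[C@H]3C(=O)OC)cc2OC)c(OC)c1`) has the same atoms and bonds as compound 3, and the two differ in a single stereo element: the two compounds have the same atoms and bonds; at least one stereo element is drawn with a configuration in one of them and without one in the other: 1 of 5 stereo elements differ; a double bond is drawn Z in compound 3 and E in compound 4. For the measured compounds named here, no measured pair in this small set shows what such a change of double bond geometry does, so the expectation rests on a thin base. Going by the values given here, the only number available, 184 ug/mL for compound 1, is also high. In this assay, no step beyond the usual scatter is expected, in either direction, and another result reported only as a limit would be no surprise. The estimated change is a step that the limit leaves unreadable from compound 3 to compound 4. For compound 4 the expected value is 220 ug/mL, with an estimated range from 130 ug/mL to 400 ug/mL.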

Compound 4, half-maximal inhibitory concentration: 158 ug/mL
Compound 4: middle estimate off by 1.4-fold (0.14 log units), on the high side, within the range that was stated.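

In this assay compound 3 gives only a limit of the assay, > 200 ug/mL, and so says nothing exact about the Z double bond in its linker. Moving that double bond to the E geometry yields a readable number for the first time at this position, and the comparison gives an at least 1.2-fold lower number from compound 3 to compound 4 (0.10 log units; that floor lies within the scatter), so the pair does not establish that the geometry moves the value beyond the usual scatter, although a larger step is not excluded. Only this floor can be read, and not the true size of the step, because one end of the pair rests on a limit: the limit of > 200 ug/mL in this assay, at which 2 of the 4 values shown sit.

Going by these compounds, whether the same change from Z to E behaves alike in a compound without the methoxy groups, such as the Z-linked compound 2, remains open. Also open, on these data alone, is how the value would respond to a longer chain in the linker, or to a free carboxylic acid in place of the methyl ester on the two proline units.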